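This account rests on a few compounds, and the source may have more. Where it says the series, first, only, none or still open, it means among the compounds named here.

Among the measured compounds shown here, compound 1 `COc1cc[nH]c1/C=C1\C(=O)Nc2ccc(F)c(C#C[C@@H](C)O)c21` gives 110 nM in a functional assay on MDA-MB-435 cells (Homo sapiens) for inhibition (a lower number here means a stronger inhibitor, a higher number a weaker inhibitor), the lowest of the three numbers measured so far. Compound 2 `COc1cc[nH]c1/C=C1\C(=O)Nc2ccc(F)c(C#C[C@@H](N)CO)c21` gives 300 nM in this assay, and compound 3 `CCN[C@H](C#Cc1c(F)ccc2c1/C(=C/c1[nH]ccc1OC)C(=O)N2)CO` gives 1160 nM. The change from compound 1 to compound 4 `CN[C@H](C#Cc1c(F)ccc2c1/C(=C/c1[nH]ccc1OC)C(=O)N2)[C@@H](C)O` is 2-hydroxy-1-(methylamino)propyl in place of 1-hydroxyethyl on a triple-bonded carbon. For the measured compounds named here, two measured steps bear on it: a 2.7-fold higher number from compound 1 to compound 2 (0.44 log units; beyond the scatter), and an 11-fold higher number from compound 1 to compound 3 (1.02 log units; beyond the scatter). A third, a 3.9-fold higher number from compound 2 to compound 3 (0.59 log units; beyond the scatter), shows the alkyl on the amine nitrogen costing more. A methylamino group stands between hydrogen and ethyl on that nitrogen, so for compound 4 a weakening step beyond the scatter is expected, a 5.5-fold higher number from compound 1 to compound 4 (0.74 log units; beyond the scatter). Compound 4 is therefore estimated at 600 nM, with a range from 250 nM to 1500 nM.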

Compound 4, half-maximal inhibitory concentration: 358 nM
For compound 4 the middle estimate is 1.7-fold (0.22 log units) above the measured one; low and high end bracket the measured number.
By their numbers in this assay, from the lowest: compound 1; then compounds 2 and 4 (each within the scatter of the next); then compound 3.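

Compound 4 shows that a 2-hydroxy-1-(methylamino)propyl chain can match the 1-amino-2-hydroxyethyl chain within the scatter (a 1.2-fold higher number from compound 2 to compound 4 (0.08 log units; within the scatter)) and improves on the ethylamino chain (a 3.2-fold lower number from compound 3 to compound 4 (0.51 log units; beyond the scatter)). It still does not recover the 1-hydroxyethyl compound (a 3.3-fold higher number from compound 1 to compound 4 (0.51 log units; beyond the scatter)), so all three amine-bearing chains on this triple-bonded carbon remain weaker than compound 1. Nothing available explains these steps. The methyl on nitrogen and the added methyl on the chain cannot be separated in compound 4. Going by these compounds, how a dimethylamino group or a carboxylic acid would fare on this chain remains open.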